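The compounds below may be only part of what the source reports. "The series", "measured", "known", "first", "only" and "open" are said of these compounds alone.

In an in vivo ADME assay on the whole organism (strain Sprague-Dawley) for pharmacokinetics, with Rattus norvegicus as the target, at a dose of 1 mg/kg by the intravenous route (on this read-out higher numbers stand for wider distribution into tissues and lower numbers for narrower distribution), compound 1 (`CNc1c(-c2ccc(=O)n(-c3ccccc3C)n2)c(-c2ccc(F)cc2)nn1C`) gives 0.65 L/kg and compound 2 (`Cc1ccccc1-n1nc(-c2c(-c3ccc(F)cc3)nn3c2NC[C@@H](O)C3)ccc1=O`) gives 1.23 L/kg as its reading, so these two values lie within the scatter of each other. Compound 3 (`Cc1ccccc1-n1nc(-c2c(-c3ccc(F)cc3)nn3c2NC[C@H](O)C3)ccc1=O`) differs from compound 2 in one respect (the two compounds have the same atoms and bonds and differ only in configuration as drawn: 1 of 1 stereo elements differ; a stereocentre at a saturated ring carbon is drawn R in compound 2 and S in compound 3), and the two compounds have the same atoms and bonds. No step beyond the scatter is expected in this assay and neither direction is favoured. The estimated step is small (a 1.0-fold lower number from compound 2 to compound 3 (0.01 log units; within the scatter)). Compound 3 is expected at 1.2 L/kg with an estimated range from 0.65 L/kg to 2.2 L/kg for its reading.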

Compound 3, volume of distribution at steady state: 4.21 L/kg
Beside the measured number, compound 3's estimate is 3.5-fold (0.55 log units) below it; measured number above the stated range.
By their numbers in this assay, from the lowest: compounds 1 and 2 (each within the scatter of the next); then compound 3.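

In this assay, inverting the stereocentre at a saturated ring carbon from R to S gives a 3.4-fold higher number from compound 2 to compound 3 (0.53 log units; beyond the scatter), a modest step but one beyond the scatter. The earlier compounds shown here offered no pair that tested configuration at this carbon, and this pair shows that distribution can respond to it. The step can be traced to configuration alone, because nothing else changes: the fact that compounds 2 and 3 differ only in the configuration as drawn

Going by these compounds, whether the higher number with S would hold on another core remains open, since this is a single pair. The compounds shown also leave open how distribution would respond to an amine or a methyl ether in place of the hydroxyl at this carbon.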